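The source may report more compounds than this note shows. Statements on the series, on what has been measured and on what is new or still open speak of the compounds shown alone.

Measured so far:
compound 1, `Cc1cncc(OC[C@@H]2CCCN2C)c1`: 0.48 nM
compound 2, `CCCCc1cncc(OC[C@@H]2CCCN2C)c1`: 0.16 nM

Both compounds share one core and differ only at a single aromatic carbon. In an assay on membranes from brain for displacement of a labelled ligand from Neuronal acetylcholine receptor; alpha4/beta2 (Rattus norvegicus) (on this read-out higher numbers stand for weaker inhibition and lower numbers for stronger inhibition), compound 1 gives 0.48 nM and compound 2 gives 0.16 nM. For the measured compounds named here, the one measured step, a 3.0-fold lower number from compound 1 to compound 2 (0.48 log units; beyond the scatter), lies beyond the scatter. Going by the values given here, compound 2 thus stands lowest of the two numbers, its only neighbour being compound 1.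

Compound 3, `CC(=O)c1cncc(OC[C@@H]2CCCN2C)c1`, has not yet been measured in this assay. Relative to compound 2 the change is acetyl in place of butyl on an aromatic carbon. Among the compounds with values here, no measured step covers the exchange of a saturated chain for a group carrying a carbonyl and an acceptor, so the expectation rests on indirect ground. Because a 3.0-fold lower number from compound 1 to compound 2 (0.48 log units; beyond the scatter) came with lengthening the chain at this carbon, and compound 3 gives that chain up, the number is expected to move back toward compound 1 rather than fall further. The step expected is a 3.1-fold higher number from compound 2 to compound 3 (0.49 log units; beyond the scatter). Compound 3 is estimated at 0.5 nM, with a range from 0.15 nM to 2 nM.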

Compound 3, inhibition constant: 1.19 nM
Compound 3: the middle estimate sits 2.4-fold (0.38 log units) below what was measured; the measured number falls inside the stated range.
By their numbers in this assay, from the lowest: compound 2; then compound 1; then compound 3.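

In this assay this aromatic carbon proves sensitive to more than chain length: acetyl in place of butyl gives a 7.4-fold higher number from compound 2 to compound 3 (0.87 log units; beyond the scatter) and acetyl in place of methyl gives a 2.5-fold higher number from compound 1 to compound 3 (0.39 log units; beyond the scatter) so compound 3 does not simply return to the level of compound 1 but passes it. Compound 3 therefore has the highest number of the three, and the order from the lowest, butyl, then methyl, then acetyl, does not follow chain size alone, since acetyl is larger than methyl yet gives the higher number. The butyl-to-acetyl exchange changes the carbon count and also brings in a double bond and a hydrogen-bond acceptor, and no available data link the size of this step to any one of these differences.

Propyl at this carbon would help separate the effect of chain size from that of the carbonyl, while an amide or a hydroxyethyl group would show whether the higher number is specific to acetyl. A longer chain such as hexyl would test whether the number keeps falling beyond butyl.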